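The source may hold more compounds than are shown below. What is called first, only, known or untested is meant among the compounds shown, and "the series" means these compounds.

Compound 1 `Cc1nc(NC(C)C)c2cnn(-c3ccccc3)c2n1` and compound 2 `Cc1nc(Nc2ccccc2)c2cnn(-c3ccccc3)c2n1` share one core and differ only in the group on the ring nitrogen. In a functional assay on G-361 cells (Homo sapiens) for cytotoxicity, read by sulforhodamine B assay (a higher number here means a weaker inhibitor of growth, a lower number a stronger inhibitor of growth), compound 1 gives 32000 nM. Compound 2 does not give a number in this assay but only a limit, at > 100000 nM, which is the upper bound of the measurement (the limit of > 100000 nM in this assay, at which 1 of the 2 values shown sits). The step of an at least 3.1-fold higher number from compound 1 to compound 2 (0.49 log units; beyond the scatter) therefore shows a weakening of growth inhibition that is at least modest, its true size unknown.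

Compound 3 `CC(C)c1nc(Nc2ccccc2)c2cnn(-c3ccccc3)c2n1` is compound 2 altered at a different place: isopropyl in place of methyl on an aromatic carbon. Going by the values given here, no measured pair shows this particular change. Among the compounds with values here, the only measured step, an at least 3.1-fold higher number from compound 1 to compound 2 (0.49 log units; beyond the scatter), concerns the group on the nitrogen, not the methyl on the aromatic carbon, so it bears on compound 3 only by fixing where compound 2 stands, namely at the limit. With nothing to suggest a direction, the step of a number no higher from compound 2 to compound 3 (the limit leaves the size open) is expected to be none beyond the scatter. Compound 3 is accordingly estimated to give 100000 nM in this assay, within a range from 30000 nM to 300000 nM, and most likely to sit again at the limit.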

Compound 3, concentration for 50% growth inhibition: 32000 nM
Estimate against measurement, compound 3: 3.1-fold (0.49 log units) above; measured number inside the range.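

In this assay, going by these compounds alone, the methyl on the aromatic carbon, which stayed unchanged across the earlier compounds, proves not to be a silent position: with the anilino group in place, isopropyl in place of methyl gives an at least 3.1-fold lower number from compound 2 to compound 3 (0.49 log units; beyond the scatter). The earlier step spoke only of the group on the nitrogen, whereas this one shows that the aromatic carbon between two ring nitrogen atoms also bears on growth inhibition, here towards stronger inhibition with the larger isopropyl group. The true size of the step stays unknown because compound 2 stands only at a limit of the assay, not at a number: the limit of > 100000 nM in this assay, at which 1 of the 3 values shown sits.

The compounds shown leave open whether the same exchange of methyl for isopropyl would act in the same direction on compound 1, which carries isopropyl rather than phenyl on the nitrogen. They also leave open how growth inhibition would respond to an ethyl, a tert-butyl or a cyclohexyl group, or to an amine, on this aromatic carbon.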